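The source may hold more compounds than are shown below. What is called first, only, known or untested is meant among the compounds shown, and "the series" means these compounds.

Of the compounds shown here, three built on one shared core have been measured in an ADME assay on HEK293 cells (Homo sapiens) for antiproliferative activity, read by MTT assay, with a stated time of 24 h; on this read-out lower numbers stand for stronger inhibition and higher numbers for weaker inhibition. Compound 1, `COc1ccc(-c2cc(C(=O)/C=C/c3ccccc3)nc3cc(-c4ccccc4)nn23)cc1OC`, gives 64100 nM, which is the highest of the three numbers recorded so far. Compound 2, `COc1cc(-c2cc(C(=O)/C=C/c3ccccc3)nc3cc(-c4ccccc4)nn23)cc(OC)c1OC`, gives 44800 nM, and compound 3, `COc1ccc(C(=O)/C=C/c2cc(-c3ccc(OC)c(OC)c3)n3nc(-c4ccccc4)cc3n2)cc1`, gives 40000 nM. Among the measured compounds shown here, the measured steps are a 1.4-fold lower number from compound 1 to compound 2 (0.16 log units; within the scatter) and a 1.6-fold lower number from compound 1 to compound 3 (0.20 log units; within the scatter); both lie within the usual scatter, so the three compounds cannot be separated on this read-out, and compound 1 is merely the one with the largest number rather than a clearly weaker compound.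

Compound 4, `COc1ccc(-c2cc(C(=O)/C=C/c3cc(OC)c(OC)c(OC)c3)nc3cc(-c4ccccc4)nn23)cc1OC`, has not yet been measured. It differs from compound 1 in one place: 3,4,5-trimethoxyphenyl in place of phenyl on a double-bonded chain carbon bound to a double-bonded chain carbon. Of the measured steps, the one bearing most directly on this change is the one where a methoxy was added on an aromatic carbon, namely a 1.4-fold lower number from compound 1 to compound 2 (0.16 log units; within the scatter), which stayed within the scatter. Adding three methoxy groups on a different ring has no direct precedent here, so the expectation rests on that single step.

Compound 4 is therefore expected to give 45000 nM, with a range from 18000 nM to 110000 nM. That estimate amounts to an expected 1.4-fold lower number from compound 1 to compound 4 (0.15 log units; within the scatter), that is, no step beyond the scatter.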

Compound 4, half-maximal inhibitory concentration: 46800 nM
Compound 4: middle estimate off by 1.0-fold (0.02 log units), on the low side; the range from low to high includes it.
By their numbers in this assay, from the lowest: compounds 3, 2, 4 and 1 (each within the scatter of the next).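

Among the compounds shown here, compound 4 is the one compound here in which the phenyl on a double-bonded chain carbon bound to a double-bonded chain carbon is exchanged while the rest of compound 1 stays the same. In this assay, the change to 3,4,5-trimethoxyphenyl gives a 1.4-fold lower number from compound 1 to compound 4 (0.14 log units; within the scatter). At this position, then, going from 6 to 12 heavy atoms and from 0 to 3 hydrogen-bond acceptors produces no step beyond the scatter, and nothing available here explains this result.

The compounds shown leave open whether any group at this position can shift the number beyond the scatter, since a single change, however large, cannot show how far this tolerance extends. A lone methoxy, an amine or a carboxylic acid on this ring could each test that, and each would show whether the result holds for groups other than 3,4,5-trimethoxyphenyl.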